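Cyclopropyl quinolone acids: chloro for fluoro, cytotoxicity read-out

The compounds below may be only part of what the source reports. "The series", "measured", "known", "first", "only" and "open" are said of these compounds alone.

Compound 1 `O=C(O)c1cn(C2CC2)c2c(F)c(N3CCCC3)c(F)cc2c1=O` carries a pyrrolidin-1-yl group and is the reference of the series. In a functional assay on V79 cells (Cricetulus griseus) for cytotoxicity, read by colony formation (on this read-out higher numbers stand for weaker inhibition and lower numbers for stronger inhibition), compound 1 gives 120 ug/mL. Compound 2 `O=C(O)c1cn(C2CC2)c2c(Cl)c(N3CCCC3)c(F)cc2c1=O` differs from it by chloro in place of fluoro on an aromatic carbon, and in this assay compound 2 gives 150 ug/mL; the step is a 1.3-fold higher number from compound 1 to compound 2 (0.10 log units; within the scatter). Compound 3 `NC1CCN(c2c(F)cc3c(=O)c(C(=O)O)cn(C4CC4)c3c2F)CC1` differs from compound 1 by 4-aminopiperidin-1-yl in place of pyrrolidin-1-yl on an aromatic carbon, and in this assay compound 3 gives 23 ug/mL, a step of a 5.2-fold lower number from compound 1 to compound 3 (0.72 log units; beyond the scatter). Compound 3 stands lowest of the three measured numbers, with both other compounds beyond the scatter from it.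

Compound 4 `NC1CCN(c2c(F)cc3c(=O)c(C(=O)O)cn(C4CC4)c3c2Cl)CC1` is not yet measured. It differs from compound 3 by chloro in place of fluoro on an aromatic carbon. This is the same kind of change as that from compound 1 to compound 2, but not the same: around the place it is ortho to a 4-aminopiperidin-1-yl group (7 heavy atoms) rather than ortho to a pyrrolidin-1-yl group (5 heavy atoms). The difference between the two cores is given by 4-aminopiperidin-1-yl in place of pyrrolidin-1-yl on an aromatic carbon. Since the earlier step was a 1.3-fold higher number from compound 1 to compound 2 (0.10 log units; within the scatter), a step of about a 1.3-fold higher number from compound 3 to compound 4 (0.12 log units; within the scatter) is expected in this assay from compound 3 to compound 4. For compound 4 the estimated value in this assay is 30 ug/mL, expected between 15 ug/mL and 60 ug/mL.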

Compound 4, half-maximal inhibitory concentration: 18 ug/mL
The estimate for compound 4 lay 1.7-fold (0.22 log units) above the measured number, within the range that was stated.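

In this assay, chloro in place of fluoro stays within the scatter on the core carrying 4-aminopiperidin-1-yl, at a 1.3-fold lower number from compound 3 to compound 4 (0.11 log units; within the scatter), and this step does not differ beyond the scatter from the one on the core carrying pyrrolidin-1-yl: the same change on two cores in this assay, a 1.3-fold higher number (0.10 log units; within the scatter) from compound 1 to compound 2 and a 1.3-fold lower number (0.11 log units; within the scatter) from compound 3 to compound 4, 1.6-fold (0.20 log units) apart, within the scatter of two such steps. The exchange of pyrrolidin-1-yl for 4-aminopiperidin-1-yl also carries over, at an 8.3-fold lower number from compound 2 to compound 4 (0.92 log units; beyond the scatter) with chloro in place, which is of like size to the step with fluoro in place: the same change on two cores in this assay, a 5.2-fold lower number (0.72 log units; beyond the scatter) from compound 1 to compound 3 and an 8.3-fold lower number (0.92 log units; beyond the scatter) from compound 2 to compound 4, 1.6-fold (0.20 log units) apart, within the scatter of two such steps. Across these four compounds the two changes therefore behave independently of each other, but each comparison rests on a single pair of cores, and agreement between two steps within the scatter shows only that chloro for fluoro does little here, not that a larger effect would transfer.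

Open, as far as these compounds go, is whether this independence holds with a piperazin-1-yl group on the same aromatic carbon. Equally open, from the compounds shown here alone, is whether it holds with a methoxy group in place of chloro or fluoro, or an ethyl group in place of cyclopropyl.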